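A few compounds are considered here, and "the series" means these few. Any claim that something is new, unique, unknown or untested is made for them only; others in the source may bear on it.

In an ADME assay on DU-145 cells (Homo sapiens) for cytotoxicity, read by MTT assay, with a stated time of 72 h (on this read-out higher numbers stand for weaker inhibition and lower numbers for stronger inhibition), compound 1 (`COC(=O)c1cc(C2=C(c3cc(OC)c(OC)c(OC)c3)C(=O)CC2O[SiH2]C(C)(C)C)ccc1OC`) gives > 100 ug/mL, which is a limit of the assay and not a number. This is the limit of > 100 ug/mL in this assay, at which 1 of the 3 values shown sits. Compound 2 (`COc1ccc(C2=C(c3cc(OC)c(OC)c(OC)c3)C(=O)C(OC(C)=O)C2)cc1F`) gives 16 ug/mL, and compound 3 (`COc1ccc(C2=C(c3cc(OC)c(OC)c(OC)c3)C(=O)C(OC(C)=O)C2)cc1Cl`) gives 64 ug/mL. Compound 4 (`COCOc1cc(C2=C(c3cc(OC)c(OC)c(OC)c3)C(=O)CC2O[SiH2]C(C)(C)C)ccc1OC`) has methoxymethoxy in place of methoxycarbonyl on an aromatic carbon, ortho to a methoxy group: methoxymethoxy in place of methoxycarbonyl on an aromatic carbon. For the measured compounds named here, no measured step covers this exchange. The nearest guide is the chloro in place of fluoro change, a 4.0-fold higher number from compound 2 to compound 3 (0.60 log units; beyond the scatter), which is modest but beyond the scatter and bears only loosely. A small move toward stronger inhibition is expected, estimated as an at least 1.1-fold lower number from compound 1 to compound 4 (0.04 log units; that floor lies within the scatter). Compound 4 is estimated at 90 ug/mL, within a range of 30 ug/mL to 200 ug/mL.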

Compound 4, half-maximal inhibitory concentration: 34 ug/mL
Estimate against measurement, compound 4: 2.6-fold (0.42 log units) above; low and high end bracket the measured number.
By their numbers in this assay, from the lowest: compound 2; then compounds 4 and 3 (each within the scatter of the next). At a limit, above all of these: compound 1.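

In this assay, methoxymethoxy in place of methoxycarbonyl on this aromatic carbon, ortho to a methoxy group, gives an at least 2.9-fold lower number from compound 1 to compound 4 (0.46 log units; beyond the scatter). The position therefore responds to an exchange of groups that match in heavy atoms and hydrogen-bond acceptors, so those counts alone do not set the read-out here. Compound 1 stands at a limit and not a number, and the full size of the step stays unknown because of this: the limit of > 100 ug/mL in this assay, at which 1 of the 4 values shown sits.

Where a hydroxyl, an amine or a carboxylic acid on this carbon would place the number remains open.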